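Tert-butyl for bromo on the aryl ether of compound 2

The compounds below may be only part of what the source reports. "The series", "measured", "known", "first", "only" and "open" are said of these compounds alone.

Measured compounds:
compound 1 `Cc1nnsc1CO/N=C/c1c(C)nn(C)c1Oc1cccc(F)c1`, > 50000 nM
compound 2 `Cc1nnsc1CO/N=C/c1c(C)nn(C)c1Oc1ccc(Br)cc1`, 15200 nM
compound 3 `Cc1cccc(Oc2c(/C=N/OCc3snnc3C)c(C)nn2C)c1`, 12800 nM

Of the compounds shown here, three sharing one core have been tested in a functional assay on SGC-7901 cells (Homo sapiens) for inhibition, read by MTT assay, with a stated time of 48 h; a higher number here means a weaker inhibitor, a lower number a stronger inhibitor. For compound 1 the result is only a limit of the assay, > 50000 nM, and so is not a number (the limit of > 50000 nM in this assay, at which 1 of the 3 values shown sits). Compound 2 gives 15200 nM in this assay, the higher of the two numbers obtained; compound 3 gives 12800 nM, and the step of a 1.2-fold lower number from compound 2 to compound 3 (0.07 log units; within the scatter) is within the scatter, so the two are not distinguishable. Against compound 1 both steps are clearer: an at least 3.2-fold lower number from compound 1 to compound 2 (0.51 log units; beyond the scatter) and an at least 3.9-fold lower number from compound 1 to compound 3 (0.59 log units; beyond the scatter).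

The untested compound 4 `Cc1nnsc1CO/N=C/c1c(C)nn(C)c1Oc1ccc(C(C)(C)C)cc1` differs from compound 2 by tert-butyl in place of bromo on an aromatic carbon. Among the measured compounds shown here, no measured step touches a tert-butyl group, and none keeps the 4-position of the phenyl ring while changing only the substituent there. The steps that exist show that exchanging one small substituent for another on this ring moves the number by a modest amount at most, and only across the scatter when compound 1 is involved. A step of no more than modest size is therefore expected from compound 2 to compound 4, with no firm direction: the estimate is a 1.3-fold lower number from compound 2 to compound 4 (0.10 log units; within the scatter). Compound 4 is expected at about 12000 nM, somewhere between 4000 nM and 45000 nM.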

Compound 4, half-maximal inhibitory concentration: > 50000 nM
Compound 4: no number, only a limit (the forecaster's own chance of this, stated with the estimate: 15%); at least 4.1-fold (0.61 log units) between middle value and limit.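

In this assay, among the compounds shown here, this is the first change that keeps the substituent at one place on the phenyl ring and alters only the group there, so it isolates that place, para to a large group, in a way the earlier steps did not: an at least 3.2-fold higher number from compound 2 to compound 4 (0.51 log units; beyond the scatter). Among the compounds shown, the number for this ring is therefore sensitive to the group at this place as well as to where a substituent sits, since bromo, with 1 heavy atom, gives way to tert-butyl, with 4 heavy atoms, and the step lies beyond the scatter. The result for compound 4 is a limit of the assay and not a number, and it is the same limit as that of compound 1: the limit of > 50000 nM in this assay, at which 2 of the 4 values shown sit.

The compounds shown leave open whether ethyl or isopropyl at this same place would keep a number near that of compound 2 or reach the limit seen for compound 4. They also do not say how a methoxy group, an amine or a carboxylic acid would behave there, so no trend across substituents at this place can be drawn from a single step.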